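Aryl swap on the chalcone chain: compound 1 to compound 4

The source may report more compounds than this note shows. Statements on the series, on what has been measured and on what is new or still open speak of the compounds shown alone.

Compound 1 `COc1cccc(/C=C/C(=O)c2ccccc2NC(=O)NS(=O)(=O)c2ccc(C)cc2)c1` is the reference. In an ADME assay on the whole organism for cytotoxicity, with Artemia salina as the target, with a stated time of 24 h (a lower number here means that less compound is needed, a higher number that more compound is needed for the effect), compound 1 gives 23.2 ug/mL, the second highest of the three numbers measured. Compound 2 `COc1ccc(/C=C/C(=O)c2ccccc2NC(=O)NS(=O)(=O)c2ccc(C)cc2)c(OC)c1` gives 16 ug/mL, and compound 3 `Cc1ccc(S(=O)(=O)NC(=O)Nc2ccccc2C(=O)/C=C/c2ccc(O)cc2)cc1` gives 24.3 ug/mL. The step of a 1.5-fold lower number from compound 1 to compound 2 (0.16 log units; within the scatter) and the step of a 1.0-fold higher number from compound 1 to compound 3 (0.02 log units; within the scatter) both replace the aryl group at the same place as the change now considered, and both stay within the scatter; the step of a 1.5-fold higher number from compound 2 to compound 3 (0.18 log units; within the scatter) does likewise. Compound 4 `CCOc1cc(/C=C/C(=O)c2ccccc2NC(=O)NS(=O)(=O)c2ccc(C)cc2)ccc1O` differs from compound 1 by 3-ethoxy-4-hydroxyphenyl in place of 3-methoxyphenyl on a double-bonded chain carbon bound to a double-bonded chain carbon. Since every measured aryl exchange at this position, including the one that introduces a hydroxyl in compound 3, left the number essentially unchanged, compound 4 is expected to sit close to compound 1, with a step of a 1.1-fold lower number from compound 1 to compound 4 (0.02 log units; within the scatter) that is expected to stay within the scatter. The estimated value for compound 4 in this assay is 22 ug/mL, expected to lie between 12 ug/mL and 40 ug/mL.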

Compound 4, concentration for half-maximal effect: 19.2 ug/mL
Compound 4: middle estimate off by 1.1-fold (0.06 log units), on the high side; the measured number falls inside the stated range.
By their numbers in this assay, from the lowest: compounds 2, 4, 1 and 3 (each within the scatter of the next).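

In this assay, the exchange to 3-ethoxy-4-hydroxyphenyl, which brings a hydrogen-bond donor together with an ethoxy on the same aryl group, gives a 1.2-fold lower number from compound 1 to compound 4 (0.08 log units; within the scatter) and so leaves the number unmoved at this place. For the compounds shown here, the first single-group change on the aryl group, ethoxy in place of hydrogen on an aromatic carbon, gives a 1.3-fold lower number from compound 3 to compound 4 (0.10 log units; within the scatter) and is no larger, while the exchange from 2,4-dimethoxyphenyl gives a 1.2-fold higher number from compound 2 to compound 4 (0.08 log units; within the scatter) and also stays within the scatter. Nothing measured here accounts for this insensitivity.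

The compounds shown carry only hydroxyl and alkoxy groups on this aryl group, so whether an amine or a carboxylic acid there would move the number beyond the scatter remains open. As far as these compounds go, whether a longer chain, such as butoxy in place of ethoxy, would do so also remains open.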